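This account rests on a few compounds, and the source may have more. Where it says the series, first, only, none or still open, it means among the compounds named here.

Measured so far in an assay on isolated protein for inhibition of Dihydrofolate reductase (Homo sapiens), read by spectrophotometry; on this read-out lower numbers stand for stronger inhibition and higher numbers for weaker inhibition:
compound 1 `CCN(Cc1nc2cc(C(F)(F)F)ccc2nc1-c1ccccc1)c1ccc(OC(F)(F)F)cc1` gives 5000 nM
compound 2 `CCN(Cc1nc2cc(C(F)(F)F)ccc2nc1-c1ccccc1)c1ccc(OC)c(OC)c1` gives 4000 nM
compound 3 `C#CCN(Cc1nc2cc(C(F)(F)F)ccc2nc1-c1ccccc1)c1ccc(OC(F)(F)F)cc1` gives 4000 nM

Compound 4 `C#CCN(Cc1nc2cc(C(F)(F)F)ccc2nc1-c1ccccc1)c1ccc(OC)c(OC)c1` has not yet been measured in this assay. Compound 2 differs from compound 1 by 3,4-dimethoxyphenyl in place of 4-(trifluoromethoxy)phenyl on an amine nitrogen, and this change gave a 1.3-fold lower number from compound 1 to compound 2 (0.10 log units; within the scatter). The same change is now taken from compound 3 to compound 4: 3,4-dimethoxyphenyl in place of 4-(trifluoromethoxy)phenyl on an amine nitrogen. The place is described in the same words in both cases, so it is the same change carried onto a second core. The two cores differ by ethynyl in place of methyl on a saturated chain carbon bound to a nitrogen on an aromatic ring, which on its own gave a 1.3-fold lower number from compound 1 to compound 3 (0.10 log units; within the scatter); the values of compound 2 and compound 3 coincide at the digits recorded. Compound 4 is expected to show a 1.3-fold lower number from compound 3 to compound 4 (0.12 log units; within the scatter), because the same change gave a 1.3-fold lower number from compound 1 to compound 2 (0.10 log units; within the scatter), a step that stays within the scatter. For compound 4 the estimate in this assay is 3000 nM, with a likely range from 1500 nM to 6500 nM.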

Compound 4, inhibition constant: 3000 nM
The estimate for compound 4 equals the measured number at the digits printed; measured number inside the range.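

In this assay, 3,4-dimethoxyphenyl in place of 4-(trifluoromethoxy)phenyl on an amine nitrogen gives a 1.3-fold lower number from compound 3 to compound 4 (0.12 log units; within the scatter), and the step is consistent across the two cores: the same change on two cores in this assay, a 1.3-fold lower number (0.10 log units; within the scatter) from compound 1 to compound 2 and a 1.3-fold lower number (0.12 log units; within the scatter) from compound 3 to compound 4, 1.1-fold (0.03 log units) apart, within the scatter of two such steps

Ethynyl in place of methyl gives a 1.3-fold lower number from compound 2 to compound 4 (0.12 log units; within the scatter), and this step is also consistent across the two cores: the same change on two cores in this assay, a 1.3-fold lower number (0.10 log units; within the scatter) from compound 1 to compound 3 and a 1.3-fold lower number (0.12 log units; within the scatter) from compound 2 to compound 4, 1.1-fold (0.03 log units) apart, within the scatter of two such steps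

Both changes therefore carry from one core to the other without a visible departure, but every step lies within the scatter, so this does not show that either change has a real effect on the number, nor how a step beyond the scatter would carry.

Still open, going by these compounds, is whether the pattern holds with an amine or a carboxylic acid on the aromatic ring in place of the methoxy groups, or with a longer chain on the amine nitrogen.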